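Hydroxylated cyclohexyl amides: clearance outlook for compound 3

A few compounds are considered here, and "the series" means these few. Any claim that something is new, unique, unknown or untested is made for them only; others in the source may bear on it.

Measured so far:
- Compound 1 `Cn1ccc(NC(=O)c2cn(Cc3ccc(-n4cccn4)cc3)c3cccnc23)n1`: in an ADME assay on liver for metabolic stability, with Liver microsome (Homo sapiens) as the target, using microsomes (on this read-out lower numbers stand for slow clearance and higher numbers for fast clearance), compound 1 gives 31 mL/min/kg
- Compound 2 `O=C(N[C@H]1CCCC[C@@H]1O)c1cn(Cc2ccc(-n3cccn3)cc2)c2cccnc12`: in this assay compound 2 gives 59 mL/min/kg

Compound 2 has the highest of the two numbers in this assay; its nearest neighbour is compound 1, and the gap, a 1.9-fold higher number from compound 1 to compound 2 (0.28 log units; within the scatter), is within the scatter, so the two are read as the same.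

Compound 3 `O=C(N[C@H]1CC[C@H](CO)CC1)c1cn(Cc2ccc(-n3cccn3)cc2)c2cccnc12` is the next analogue. The change from compound 2 is 4-(hydroxymethyl)cyclohexyl in place of 2-hydroxycyclohexyl on an amide-type nitrogen. Going by the values given here, no measured step alters the hydroxycyclohexyl group itself; the only step known, a 1.9-fold higher number from compound 1 to compound 2 (0.28 log units; within the scatter), swaps a heteroaryl amide substituent for the hydroxycyclohexyl and stays within the scatter. It bears only loosely on the present change, which keeps the ring and a single hydroxyl while moving it onto a one-carbon arm. In this assay no step beyond the scatter is therefore expected for compound 3, with a 1.1-fold lower number from compound 2 to compound 3 (0.03 log units; within the scatter) as the estimated step. Compound 3 is estimated at 55 mL/min/kg, in the range 28 mL/min/kg to 110 mL/min/kg.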

Compound 3, clearance: 8.5 mL/min/kg
The estimate for compound 3 lay 6.5-fold (0.81 log units) above the measured number; the measured number lies below the stated range.
By their numbers in this assay, from the lowest: compound 3; then compounds 1 and 2 (each within the scatter of the next).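

In this assay, the substituent on the amide-type nitrogen proves able to move the read-out: there is a 6.9-fold lower number from compound 2 to compound 3 (0.84 log units; beyond the scatter) with 4-(hydroxymethyl)cyclohexyl in place of 2-hydroxycyclohexyl, even though both groups carry one six-membered carbon ring and the same printed donor and acceptor counts, and neither has a net charge. Compound 3 also separates from the heteroaryl amide, with a 3.6-fold lower number from compound 1 to compound 3 (0.56 log units; beyond the scatter) on replacing 1-methyl-1H-pyrazol-3-yl, so a hydroxylated cyclohexyl on this nitrogen does not in itself fix the outcome: the 2-hydroxycyclohexyl of compound 2 stayed within the scatter of that heteroaryl amide, while the 4-(hydroxymethyl)cyclohexyl of compound 3 did not. No supporting data bear on why the two hydroxylated groups part so clearly in this assay.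

This single change alters the place of the hydroxyl on the ring, adds a one-carbon arm and changes the stereocentres together, and the compounds shown do not separate these contributions. Also open, as far as these compounds go, is how this assay would respond to a longer chain such as 2-hydroxyethyl on the cyclohexyl, or to an amine or a carboxylic acid in place of the hydroxyl.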